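A new aryl group on the ring nitrogen

The source may hold more compounds than are shown below. What is called first, only, known or untested is meant among the compounds shown, and "the series" means these compounds.

Values in a functional assay on A549 cells (Homo sapiens) for antiproliferative activity, read by MTT assay, with a stated time of 72 h; a higher number here means a weaker inhibitor, a lower number a stronger inhibitor:
Compound 1 `O=C1COc2ccc(-c3cccc(NS(=O)(=O)c4ccc(F)cc4)c3)cc2N1`: 32100 nM
Compound 2 `COc1ncc(-c2ccc3c(c2)N(C2CCCCC2)C(=O)CO3)cc1NS(=O)(=O)c1ccc(F)cc1`: 24600 nM
Compound 3 `CC(C)N1C(=O)COc2ccc(-c3cnc(Cl)c(NS(=O)(=O)c4ccc(F)cc4)c3)cc21`: 5100 nM

Compound 1, at 32100 nM, sits at the weak end of this small set. Compound 2, at 24600 nM, lies within the usual scatter of it, so the two cannot be told apart. Compound 3, at 5100 nM, shows a clearly lower number than either.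

Compound 4 `COc1cccc(N2C(=O)COc3ccc(-c4cccc(NS(=O)(=O)c5ccc(F)cc5)c4)cc32)c1` keeps the core of compound 1 but carries a 3-methoxyphenyl in place of hydrogen on an amide-type nitrogen in a ring.

For the measured compounds named here, no measured pair isolates this change. Compounds 2 and 3 also carry a group on that nitrogen, but they differ from compound 1 elsewhere too, so they are only a loose guide. Their values still suggest that such a group need not weaken activity in this assay. A modest gain is expected, shown by the estimated 2.3-fold lower number from compound 1 to compound 4 (0.36 log units; beyond the scatter). Compound 4 is expected to give about 14000 nM, with an estimated range of 4000 nM to 45000 nM.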

Compound 4, half-maximal inhibitory concentration: > 40000 nM
Compound 4: a limit, no number (the forecaster's own chance of this, stated with the estimate: 15%); middle value at least 2.8-fold (0.45 log units) from the limit.
By their numbers in this assay, from the lowest: compound 3; then compounds 2 and 1 (each within the scatter of the next). At a limit, above all of these: compound 4.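

In this assay compound 4 gives > 40000 nM, which is a limit of the assay and not a number. For the compounds shown here, the one step that isolates this position is an at least 1.2-fold higher number from compound 1 to compound 4 (0.09 log units; that floor lies within the scatter), so placing 3-methoxyphenyl in place of hydrogen on the amide-type nitrogen gives no sign of a gain on the core of compound 1, though whether it truly costs activity cannot be read. The result at this position is therefore a floor and not a measured size: the limit of > 40000 nM in this assay, at which 1 of the 4 values shown sits.

The compounds shown leave open how this nitrogen behaves on the same core with a plain phenyl, a small methyl, or a longer chain ending in an amine. Going by these compounds alone, they also leave open whether the methoxy group of compound 4 matters at all, since no pair separates it from the aromatic ring that carries it.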